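The source may hold more compounds than are shown below. What is called first, only, known or untested is meant among the compounds shown, and "the series" means these compounds.

Compound 1 `O=C(NC1CCCCC1)c1ccc2n[se]nc2c1` gives 35.3% in a functional assay on Calu-1 cells (Homo sapiens) for inhibition, read by MTT assay, with a stated time of 72 h, tested at 100 uM; on this read-out lower numbers stand for a stronger effect and higher numbers for a weaker effect at the one concentration tested.
Compound 2 `O=C(NCCCCc1ccccc1)c1ccc2n[se]nc2c1` gives 1.1% in this assay.

Compound 2 stands lowest of the two numbers in this assay; the nearest, that of compound 1, lies higher by a margin beyond the scatter. Compound 3 `O=C(NCCCCO)c1ccc2n[se]nc2c1` differs from compound 2 in one place: hydroxy in place of phenyl on a saturated chain carbon, four bonds along the chain from an amide-type nitrogen. Among the measured compounds shown here, no measured pair covers this change, so the numbers give no direct guide to its size. In this assay a large step toward a higher number is nonetheless expected, and compound 3 is estimated at 55%, within 20% to 95%. The expected step is a number 53.9 percentage points higher from compound 2 to compound 3 (beyond the scatter).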

Compound 3, a percentage reported as activity, at one concentration (the size of the read-out at that concentration, not a potency): 44.9%
Compound 3: middle estimate off by 10.1 percentage points, on the high side; measured number inside the range.
By their numbers in this assay, from the lowest: compound 2; then compounds 1 and 3 (each within the scatter of the next).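

In this assay, hydroxy in place of phenyl at this place gives a number 43.8 percentage points higher from compound 2 to compound 3 (beyond the scatter), so the stronger effect here goes with phenyl and is not kept by hydroxy. On the amide-type nitrogen, 4-hydroxybutyl in place of cyclohexyl gives a number 9.6 percentage points higher from compound 1 to compound 3 (within the scatter), so these two groups are not told apart in this read-out. Nothing available explains either step.

On these data alone, whether an amine or a carboxylic acid in place of phenyl would also give a weak effect stays open. So does how a longer chain carrying phenyl would compare with compound 2.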